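A few compounds are considered here, and "the series" means these few. Any claim that something is new, unique, unknown or untested is made for them only; others in the source may bear on it.

Compound 1 `Cc1cc(NC(=O)Nc2ccc(C(F)(F)F)cc2)c2ccccc2n1` stands lowest of the two numbers recorded so far in a physicochemical assay for solubility, at pH 7.4 (on this read-out higher numbers stand for higher solubility and lower numbers for lower solubility), giving 100 nM. Compound 2 `Cc1cc(NC(=O)Nc2cccc(OC(F)(F)F)c2)c2ccccc2n1` gives 600 nM in this assay, a higher number beyond the scatter; the two structures differ in more than one place, so only their values are set side by side. Compound 3 `Cc1cc(NC(=O)Nc2ccc(Cl)cc2)c2ccccc2n1` differs from compound 1 in a single place: chloro in place of trifluoromethyl on an aromatic carbon. Within the data shown here, no measured pair covers this change, so the size of the step is unknown. For compound 3 a small upward step, a 1.5-fold higher number from compound 1 to compound 3 (0.18 log units; within the scatter), is expected, near the edge of the scatter. Compound 3 is estimated at 150 nM, with a range from 60 nM to 400 nM.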

Compound 3, solubility: 1400 nM
The estimate for compound 3 lay 9.3-fold (0.97 log units) below the measured number; the whole stated range lies below it.
By their numbers in this assay, from the lowest: compound 1; then compound 2; then compound 3.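

At this position, on an aromatic carbon para to a large group, the read-out in this assay depends strongly on the substituent: chloro in place of trifluoromethyl gives a 14-fold higher number from compound 1 to compound 3 (1.15 log units; beyond the scatter) with the rest of the structure unchanged. Among these compounds, this is the first single-change step, and it is large. Nothing measured on these compounds accounts for its size.

A single pair cannot show whether the step follows from the entry of chloro or the departure of trifluoromethyl. Going by these compounds, how a methoxy group, an amine or a carboxylic acid at this carbon would read remains open.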